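From 4-methylpiperazin-1-yl to 3-hydroxyazetidin-1-yl

This account rests on a few compounds, and the source may have more. Where it says the series, first, only, none or still open, it means among the compounds named here.

Values measured in a physicochemical assay for solubility, in phosphate buffer, with a stated time of 2 h (a higher number here means a more soluble compound, a lower number a less soluble compound), are as follows
- compound 1 `CCCCc1ccc(-c2nc(C)c(/C(C)=N/NC(=N)N)s2)cc1` gives 62500 nM
- compound 2 `C/C(=N\NC(=N)N)c1sc(-c2ccc(-c3ccccc3)cc2)nc1C` gives 2700 nM
- compound 3 `Cc1nc(-c2ccc(-c3ccccc3)cc2)sc1-c1nnc(N2CCN(C)CC2)o1` gives 45000 nM

Compound 3 lies within the scatter of compound 1, and its number is well above that of compound 2. The next compound to be measured is compound 4 `Cc1nc(-c2ccc(-c3ccccc3)cc2)sc1-c1nnc(N2CC(O)C2)o1`, which differs from compound 3 in one place (3-hydroxyazetidin-1-yl in place of 4-methylpiperazin-1-yl on an aromatic carbon): 3-hydroxyazetidin-1-yl in place of 4-methylpiperazin-1-yl on an aromatic carbon is the counted difference.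

For the measured compounds named here, only one measured step is available, a 23-fold lower number from compound 1 to compound 2 (1.36 log units; beyond the scatter), and it is a different change, phenyl in place of butyl on an aromatic carbon. It bears on this question only indirectly, showing that a single change in this small set can move the number a long way. Compound 2 also lacks 4-methylpiperazin-1-yl and gives 2700 nM in this assay, which points to a lower number for compound 4. Compound 1 goes against this reading, since it lacks that group too and gives 62500 nM as its value. A moderate fall is therefore expected, with an estimated step of a 3.8-fold lower number from compound 3 to compound 4 (0.57 log units; beyond the scatter) in this assay as the working figure. For compound 4 the expected value is 12000 nM, with an estimated range from 3000 nM to 45000 nM as the likely span.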

Compound 4, solubility: 150000 nM
Compound 4: the middle estimate sits 13-fold (1.10 log units) below what was measured; the whole stated range lies below it.
By their numbers in this assay, from the lowest: compound 2; then compounds 3 and 1 (each within the scatter of the next); then compound 4.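

In this assay, the place on an aromatic carbon of the five-membered aromatic ring with 2 nitrogen and 1 oxygen proves responsive to a single change: 3-hydroxyazetidin-1-yl in place of 4-methylpiperazin-1-yl gives a 3.3-fold higher number from compound 3 to compound 4 (0.52 log units; beyond the scatter) and so moves the number upward, by a modest step. For the compounds shown here, the only earlier step was a 23-fold lower number from compound 1 to compound 2 (1.36 log units; beyond the scatter) for phenyl in place of butyl, a different change in a different place that went the other way, so compound 4 is the first case here of a single change raising the number. This swap alters the ring size, the heavy atom count and the donor count together, and nothing available separates these or gives a reason for the rise.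

From the compounds shown here alone, it remains open whether the hydroxyl itself matters, which a plain azetidine, a 3-aminoazetidine or a morpholine at the same place would begin to address. Going by these compounds, it also remains open whether 3-hydroxyazetidin-1-yl would give a step of similar size and direction with butyl in place of the terminal phenyl of the shared core.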